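This account rests on a few compounds, and the source may have more. Where it says the series, first, only, none or still open, it means among the compounds named here.

Compound 1, `O=c1ccn([C@@H]2O[C@H](COP(=O)(O)OP(=O)(O)O)[C@@H](O)[C@H]2O)c(SCCc2ccccc2)n1`, is a diphosphate carrying a phenethylsulfanyl group on its core. In an in vitro functional assay on 1321-N1 cells for agonist activity at P2Y purinoceptor 2 (Homo sapiens), read by scintillation proximity assay and inositol phosphate accumulation (a higher number here means that more compound is needed for the effect, a lower number that less compound is needed), compound 1 gives 544 nM, the lowest of the two numbers shown, with compound 3 as its nearest neighbour. Compound 3, `O=c1ccn([C@@H]2O[C@H](COP(=O)(O)O)[C@@H](O)[C@H]2O)c(SCCc2ccccc2)n1`, keeps the phenethylsulfanyl group but carries only a monophosphate; in this assay compound 3 gives 1300 nM, and the step of a 2.4-fold higher number from compound 1 to compound 3 (0.38 log units; beyond the scatter) is modest. Compound 2, `O=c1ccn([C@@H]2O[C@H](COP(=O)(O)O)[C@@H](O)[C@H]2O)c(SCc2ccccc2)n1`, has benzylsulfanyl in place of phenethylsulfanyl on the monophosphate. In this assay compound 2 reaches only the limit >= 100000 nM, a limit of the assay rather than a number. The step of an at least 76-fold lower number from compound 2 to compound 3 (1.88 log units; beyond the scatter) is large, showing that the group on this position of the core strongly governs the read-out.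

Compound 4, `CNc1nc(=O)ccn1[C@@H]1O[C@H](COP(=O)(O)OP(=O)(O)O)[C@@H](O)[C@H]1O`, differs from compound 1 as follows: methylamino in place of phenethylsulfanyl on an aromatic carbon. For the measured compounds named here, no measured step covers this exact replacement; the only bearing comes from compound 2 and compound 3, where a small shortening of the same group moved the number to the limit. An unfavourable step is therefore expected, a 9.2-fold higher number from compound 1 to compound 4 (0.96 log units; beyond the scatter), though its size is uncertain. Compound 4 is estimated at 5000 nM, within 1000 nM to 30000 nM.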

Compound 4, half-maximal effective concentration: 7600 nM
The estimate for compound 4 lay 1.5-fold (0.18 log units) below the measured number; the range from low to high includes it.
By their numbers in this assay, from the lowest: compound 1; then compound 3; then compound 4. At a limit, above all of these: compound 2.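

In this assay, the group on an aromatic carbon between two ring nitrogen atoms also governs the read-out on the diphosphate, not only on the monophosphate, with a 14-fold higher number from compound 1 to compound 4 (1.15 log units; beyond the scatter) when methylamino enters. The change removes the sulfur, the phenyl ring and most of the chain in one step, so it reaches well beyond the shortening of the chain seen earlier. Even so, compound 4 gives a measured number rather than a limit, so neither the sulfur nor the ring is required for a measurable number on the diphosphate. Nothing measured here gives a cause for this step.

Methylamino replaces the sulfur and the ring at once, so the share of each in the step stays open. From the compounds shown here alone, how phenethylamino or methylsulfanyl would read on the diphosphate is unknown, as is the effect of a longer chain such as phenylpropylsulfanyl.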